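The source may report more compounds than this note shows. Statements on the series, on what has been measured and on what is new or still open speak of the compounds shown alone.

Measured so far:
- compound 1 `COc1ccc(-c2nc(SCC(=O)c3sc(-c4ccccc4)nc3C)[nH]c(=O)c2C#N)cc1`: 90.4%
- compound 2 `COc1ccc(-c2nc(C)c(C(=O)CSc3nc(N)c(C#N)c(-c4ccccc4)n3)s2)cc1`: 57.8%
- compound 3 `COc1ccc(-c2nc(C)c(C(=O)CSc3nc(-c4ccc(Cl)cc4)c(C#N)c(=O)[nH]3)s2)cc1`: 92.7%

In a functional assay on U-87MG ATCC cells for antiproliferative activity against U-87 MG (Homo sapiens), read by MTT assay, with a stated time of 48 h, tested at 10 uM (on this read-out lower numbers stand for a stronger effect and higher numbers for a weaker effect at the one concentration tested), compound 3 gives 92.7%, the top number of the three. Compound 1 gives 90.4%, which lies within the scatter of compound 3, so the two cannot be ordered. Compound 2 gives 57.8%, and that gap to compound 3 is beyond the scatter; compound 2 is the only one of the three with a clearly stronger read-out in this assay.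

Compound 4 `COc1ccc(-c2nc(C)c(C(=O)CSc3nc(-c4ccc(OC)cc4)c(C#N)c(=O)[nH]3)s2)cc1` is not yet measured. It differs from compound 3 in one place: methoxy in place of chloro on an aromatic carbon. Among the compounds with values here, no pair of measured compounds shows this change alone, so no step of this kind can be taken from the data. The shared core of compound 3 and the whole remaining structure are kept in compound 4, and compound 3 already sits near the weak end of the read-out, leaving little room for a weaker number.

For compound 4 the step is expected to be a number 1.7 percentage points lower from compound 3 to compound 4 (within the scatter), no larger than the scatter and with no firm direction. Compound 4 is expected to give 91% in this assay, in a range from 78% to 100%.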

Compound 4, a percentage reported as activity, at one concentration (the size of the read-out at that concentration, not a potency): 80.3%
Beside the measured number, compound 4's estimate is 10.7 percentage points above it, and the stated range covers the measured number.
By their numbers in this assay, from the lowest: compound 2; then compound 4; then compounds 1 and 3 (each within the scatter of the next).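

In this assay, the swap of 4-chlorophenyl to 4-methoxyphenyl gives a number 12.4 percentage points lower from compound 3 to compound 4 (beyond the scatter), so this aromatic carbon, para to a large group, responds to the substituent it carries, though the step is modest. Methoxy in place of hydrogen on an aromatic carbon gives a number 10.1 percentage points lower from compound 1 to compound 4 (beyond the scatter), a step of similar size, and compound 4 is the only one of these compounds that links both changes. Nothing available on these compounds accounts for either step.

The compounds shown leave open how an amine, a carboxylic acid or a longer alkoxy chain at this para carbon would read, and whether any such group would extend the step seen with methoxy. With a single tested concentration, these numbers tell only of a stronger or weaker effect at that concentration for compound 4.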